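Capping the hydroxy group of compound 1

The source may report more compounds than this note shows. Statements on the series, on what has been measured and on what is new or still open speak of the compounds shown alone.

Compound 1 `Oc1ccc2nc(-c3ccccc3)cc(O)c2c1` has been measured in a functional assay on A549 cells (Homo sapiens) for cytotoxicity (a lower number here means that less compound is needed, a higher number that more compound is needed for the effect), and compound 1 gives 8.14 ug/mL there. For the measured compounds named here, this is the higher of the two numbers so far. Compound 2 `Oc1cc(-c2ccccc2)nc2cc(F)ccc12` gives 0.96 ug/mL in the same test, a gap beyond the usual scatter, so compound 1 needs more material for the effect. The next molecule, compound 3 `COc1ccc2nc(-c3ccccc3)cc(O)c2c1`, carries one change from compound 1: methyl in place of hydrogen on an oxygen on an aromatic ring (methyl in place of hydrogen on an oxygen on an aromatic ring, or hydroxy to methoxy). Going by the values given here, no measured pair shows this change, so any forecast is loose. The step expected in this assay is a modest one toward a lower number (a 2.3-fold lower number from compound 1 to compound 3 (0.37 log units; beyond the scatter)), near the edge of the scatter. For compound 3 the estimated value is 3.5 ug/mL with an expected range from 1 ug/mL to 12 ug/mL in this test.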

Compound 3, half-maximal effective concentration: 0.19 ug/mL
Estimate against measurement, compound 3: 18-fold (1.27 log units) above, outside the stated range (below it).
By their numbers in this assay, from the lowest: compound 3; then compound 2; then compound 1.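

Swapping the hydrogen on this oxygen for methyl, the change from hydroxy to methoxy, is far from a neutral edit in this assay: it gives a 43-fold lower number from compound 1 to compound 3 (1.63 log units; beyond the scatter), a large step. For the compounds shown here, the two earlier compounds differ in more than one place, so they could not single out this oxygen; this pair is the first direct sign that what sits on it strongly shifts the amount of compound needed. Nothing available here explains why the step is so large.

On these data alone, it remains open whether the effect belongs to methyl alone or would persist with a longer chain such as ethyl, or with an acetyl group, on the same oxygen. A single pair also cannot show whether hydroxy to methoxy would give a similar step on a different core.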